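A few compounds are considered here, and "the series" means these few. Any claim that something is new, unique, unknown or untested is made for them only; others in the source may bear on it.

Measured compounds:
compound 1 `CCN(CC)C(=S)SCc1ccc2nc(C)nc(O)c2c1` — 4400 nM
compound 2 `Cc1nc(O)c2cc(CS/C(S)=N/CCCN(C)C)ccc2n1` — 25600 nM
compound 3 `Cc1nc(O)c2cc(CSC(=S)N(C3CCCCC3)C3CCCCC3)ccc2n1` — 7600 nM

In a functional assay on K562 cells (Homo sapiens) for cytotoxicity (on this read-out lower numbers stand for stronger inhibition and higher numbers for weaker inhibition), compound 2 gives the highest of the three numbers. Compound 3 sits nearest to it, with a lower number that lies beyond the scatter, and compound 1 sits furthest, also with a lower number beyond the scatter. Among the measured compounds shown here, the three compounds differ from one another in more than one place, so no single step between them can be isolated.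

Compound 4 `Cc1nc(O)c2cc(CS/C(S)=N/Cc3ccccc3)ccc2n1` is not yet measured. It differs from compound 2 by phenyl in place of 2-(dimethylamino)ethyl on a saturated chain carbon bound to a double-bonded nitrogen; the group that enters carries no hydrogen-bond acceptor, where the group that leaves carries one. Both compounds that give lower numbers than compound 2 in this assay lack a chain of this kind, which is the only pointer available. A step in the downward direction, of a size beyond the scatter, is expected, but the reading rests on three compounds only. For compound 4 the expected value in this assay is 8000 nM, with a range of 3000 nM to 25000 nM. This estimate means a step of a 3.2-fold lower number from compound 2 to compound 4 (0.51 log units; beyond the scatter).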

Compound 4, half-maximal inhibitory concentration: 4000 nM
Compound 4: the middle estimate sits 2.0-fold (0.30 log units) above what was measured; the range from low to high includes it.
By their numbers in this assay, from the lowest: compounds 4, 1 and 3 (each within the scatter of the next); then compound 2.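

The series now has its first single-place reading: this assay shows a 6.4-fold lower number from compound 2 to compound 4 (0.81 log units; beyond the scatter) when phenyl takes the place of 2-(dimethylamino)ethyl on a saturated chain carbon bound to a double-bonded nitrogen. The number therefore responds to the group carried at this place, and within this pair the dimethylamino group is not needed for the lower number. Nothing at hand accounts for the size or direction of this step.

The change removes the dimethylamino group and brings in the aromatic ring in one step, so the compounds shown do not tell which of the two carries the shift. A plain butyl chain, with neither the dimethylamino group nor the ring, or a pyridine ring in place of phenyl would help separate the two.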